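The source may report more compounds than this note shows. Statements on the series, on what has been measured and on what is new or still open speak of the compounds shown alone.

Measured so far in a functional assay (B cells) with Mus musculus as the target; a lower number here means that less compound is needed, a higher number that more compound is needed for the effect:
- compound 1 `CCOC(=O)Cn1c(=O)n(C2OC(CO)[C@@H](O)[C@H]2O)c2nc(N)nc(O)c21`: 48 uM
- compound 2 `Nc1nc(O)c2c(n1)n(C1OC(CO)[C@@H](O)[C@H]1O)c(=O)n2Cc1ccc([N+](=O)[O-])cc1`: 40 uM

Compound 2 and compound 1 share a core and differ only in the group on the saturated chain carbon bound to an aromatic nitrogen; the step of a 1.2-fold lower number from compound 1 to compound 2 (0.08 log units; within the scatter) places the two values within the scatter of each other, so neither can be called the stronger.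

Compound 3 `Nc1nc(O)c2c(n1)n(C1OC(CO)[C@@H](O)[C@H]1O)c(=O)n2Cc1ccccc1` is not yet measured. Its difference from compound 2 is hydrogen in place of nitro on an aromatic carbon. Among the measured compounds shown here, no measured step touches the nitro group: the one step available, from compound 1 to compound 2, swaps the whole group on the chain carbon, and it was itself within the scatter. Nothing here therefore points in either direction, and the estimate for compound 3 in this assay is 45 uM (range 15 uM to 130 uM), which amounts to an expected step of a 1.1-fold higher number from compound 2 to compound 3 (0.05 log units; within the scatter), with a wide range because no comparable change has been measured.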

Compound 3, concentration for half-maximal effect: 6 uM
The estimate for compound 3 lay 7.5-fold (0.88 log units) above the measured number, outside the stated range (below it).
By their numbers in this assay, from the lowest: compound 3; then compounds 2 and 1 (each within the scatter of the next).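

In this assay, taking the nitro group off the benzyl ring gives a 6.7-fold lower number from compound 2 to compound 3 (0.82 log units; beyond the scatter), so a single substituent on this aromatic carbon can shift the number clearly, which the earlier pair could not show. Phenyl in place of ethoxycarbonyl on the chain carbon gives an 8.0-fold lower number from compound 1 to compound 3 (0.90 log units; beyond the scatter), so the group at this position does matter, even though 4-nitrophenyl and ethoxycarbonyl could not be told apart there. No available measurement gives a reason for this difference.

Going by these compounds, it remains open whether any group on that aromatic carbon would raise the number as nitro does, or whether an amine, a methoxy group or a chlorine would leave it near that of compound 3. Also open, on these data alone, is how a longer chain between the phenyl ring and the shared core would behave.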